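The source may hold more compounds than are shown below. What is called first, only, known or untested is meant among the compounds shown, and "the series" means these compounds.

Compound 1, `COC(=O)c1c(-c2ccc([N+](=O)[O-])cc2)oc2ccccc2c1=O`, gives > 25 ug/mL in a functional assay on Malme-3M cells (Homo sapiens) for cytotoxicity, read by MTT assay, with a stated time of 6 days (on this read-out lower numbers stand for an effect already at smaller amounts and higher numbers for an effect only at larger amounts of compound), which is a limit of the assay and not a number.
Compound 2, `COC(=O)c1c(-c2ccc(N)cc2)oc2ccccc2c1=O`, gives > 25 ug/mL in this assay, again a limit rather than a number.
Compound 3, `O=c1cc(-c2ccc([N+](=O)[O-])cc2)oc2cc(O)ccc12`, gives > 25 ug/mL in this assay, also a limit.

All three measured values therefore sit at the same place, (the limit of > 25 ug/mL in this assay, at which 3 of the 3 values shown sit), and none of them fixes a number. From compound 1 to compound 2 the structural change is amino in place of nitro on an aromatic carbon. The step that the two limits leave unreadable from compound 1 to compound 2 cannot be read, since both ends are limits.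

Compound 4, `Nc1ccc(-c2cc(=O)c3ccc(O)cc3o2)cc1`, has not yet been measured. It differs from compound 3 by amino in place of nitro on an aromatic carbon, the same change as made from compound 1 to compound 2, at a place described in the same words. How the core of compound 3 differs from the core of compound 1 is not broken down here.

In this assay the step from compound 3 to compound 4 is expected to be a step that the limit leaves unreadable from compound 3 to compound 4, an expectation that rests on compound 1 and compound 2, whose step that the two limits leave unreadable from compound 1 to compound 2 stayed unreadable at the limit (the limit of > 25 ug/mL in this assay, at which 3 of the 3 values shown sit). Compound 4 is thus expected to give around 35 ug/mL, most probably reported again only as a limit, somewhere between 10 ug/mL and 120 ug/mL.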

Compound 4, concentration for half-maximal effect: > 25 ug/mL
Compound 4 ended at the assay's limit; the forecaster's own chance of this, stated with the estimate: 75%; the middle value does not contradict the limit.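

Compound 3 and compound 4 both end at a limit in this assay and not at a number, and the step between them cannot be read. The compounds shown leave open whether amino in place of nitro changes the effect at all, and how much compound any of them would need, with every value resting at the same place: the limit of > 25 ug/mL in this assay, at which 4 of the 4 values shown sit.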